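The source may hold more compounds than are shown below. What is called first, only, known or untested is meant among the compounds shown, and "the series" means these compounds.

Measured compounds in a functional assay on NCI-H522 cells (Homo sapiens) for inhibition; on this read-out lower numbers stand for stronger inhibition of growth and higher numbers for weaker inhibition of growth:
- compound 1, `COc1cc(/C=C/C(=O)c2cccc(-n3cc(-c4ccc(Cl)cc4)[nH]c3=O)c2)ccc1O`: 2360 nM
- compound 2, `COc1cc(/C=C/C(=O)c2cccc(-n3cc(-c4ccccc4)[nH]c3=O)c2)cc(OC)c1OC`: 950 nM
- compound 3, `O=C(/C=C/c1cccc(O)c1)c1cccc(-n2cc(-c3ccc(Cl)cc3)[nH]c2=O)c1`: 1650 nM

Compound 2 gives the lowest number of the three in this assay; compound 3 sits within the scatter of it, and compound 1 lies beyond the scatter above it. Going by the values given here, the one single-point step on record, a 1.4-fold lower number from compound 1 to compound 3 (0.16 log units; within the scatter), concerns the aryl on the double-bonded chain carbon and is itself within the scatter.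

Compound 4, `COc1cc(/C=C/C(=O)c2cccc(-n3cc(-c4cc(OC)c(OC)c(OC)c4)[nH]c3=O)c2)cc(OC)c1OC`, is not yet measured. It differs from compound 2 by one change: 3,4,5-trimethoxyphenyl in place of phenyl on an aromatic carbon.

Among the compounds with values here, no measured step touches the aryl on the aromatic carbon of the five-membered ring; all three measured compounds carry either phenyl or 4-chlorophenyl there, and the values of compound 1 and compound 3 next to compound 2 speak only for the other aryl. Within the data shown here, the sole recorded step is small, and nothing shows a large swing from any single change. Without a bearing step, the expectation is no step beyond the scatter in this assay in either direction, with a wide range to allow for an untested change.

Compound 4 is thus estimated at 1000 nM, range 350 nM to 3000 nM, an expected step of a 1.1-fold higher number from compound 2 to compound 4 (0.02 log units; within the scatter).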

Compound 4, concentration for 50% growth inhibition: 1050 nM
Compound 4: the middle estimate sits 1.1-fold (0.02 log units) below what was measured, within the range that was stated.
By their numbers in this assay, from the lowest: compounds 2, 4, 3 and 1 (each within the scatter of the next, the first and the last beyond it).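

Going by these compounds alone, this is the first step on record at the aromatic carbon of the five-membered aromatic ring, and in this assay it reads as a 1.1-fold higher number from compound 2 to compound 4 (0.04 log units; within the scatter), so 3,4,5-trimethoxyphenyl in place of phenyl leaves the number within the scatter. The position therefore carries the larger aryl, with 12 heavy atoms against 6 and 3 hydrogen-bond acceptors against 0, without a step beyond the scatter, at least where 3,4,5-trimethoxyphenyl also stands on the double-bonded chain carbon, as it does in both compounds of this pair. No measurement at hand offers an explanation for this flat result.

The compounds shown do not say whether a basic amine, a carboxylic acid or a longer chain on the para carbon of the phenyl at this position would leave the number equally unmoved, nor whether a plain methyl in place of the aryl would keep it there. They also leave open whether the same change stays within the scatter when 3-hydroxyphenyl, as in compound 3, stands on the double-bonded chain carbon.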